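The source may report more compounds than this note shows. Statements on the series, on what has been measured and on what is new or still open speak of the compounds shown alone.

The measured compounds:

Compound 1, `Nc1cccc(-c2csc(NC(=O)CCCCCC(=O)Nc3ccccc3N)n2)c1`: > 30000 nM
Compound 2, `CC(C)(C)OC(=O)Nc1cccc(-c2csc(NC(=O)CCCCCC(=O)NO)n2)c1`: < 0.17 nM

Both values come from an assay on isolated protein for inhibition of protein deacetylase HDAC6 (Homo sapiens), read by fluorescence, with a stated time of 17 h; on this read-out higher numbers stand for weaker inhibition and lower numbers for stronger inhibition. In this assay compound 1 gives > 30000 nM, and this is a limit of the measurement rather than a number: compound 1 sits at the limit of > 30000 nM in this assay, at which 1 of the 2 values shown sits, so its inhibition is too weak to be put into a figure. Compound 2 gives < 0.17 nM, again a limit, at the limit of < 0.17 nM in this assay, at which 1 of the 2 values shown sits. The two compounds differ in more than one place, so the pair shows only that one end of the measurable range holds compound 1 and the other holds compound 2.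

Compound 3, `CC(=O)Nc1cccc(-c2csc(NC(=O)CCCCCC(=O)Nc3ccccc3N)n2)c1`, differs from compound 1 in one place: acetyl in place of hydrogen on a nitrogen on an aromatic ring. For the measured compounds named here, no measured pair tells how far such a change moves the value. Compound 1 offers only a limit to start from, and nothing shown here says how an acetyl in place of hydrogen on that nitrogen shifts inhibition, so a step within the usual scatter is the plainest expectation. Compound 3 is therefore estimated at 25000 nM, with a range from 3000 nM to 100000 nM, which means an expected step of an at least 1.2-fold lower number from compound 1 to compound 3 (0.07 log units; that floor lies within the scatter).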

Compound 3, half-maximal inhibitory concentration: 11200 nM
Beside the measured number, compound 3's estimate is 2.2-fold (0.35 log units) above it; measured number inside the range.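

For the compounds shown here, replacing the hydrogen on this nitrogen with an acetyl, which turns 3-aminophenyl into 3-acetamidophenyl, gives the first pair of compounds that differ in only one place, and in this assay it brings an at least 2.6-fold lower number from compound 1 to compound 3 (0.42 log units; beyond the scatter). This step lies beyond the usual scatter, so the nitrogen on this aromatic ring is a place where a change can alter inhibition of the enzyme. Compound 3 gives a measured number, 11200 nM. The step is a floor and its full size stays unknown because compound 1 stands at a limit of the measurement rather than at a number: the limit of > 30000 nM in this assay, at which 1 of the 3 values shown sits.

The compounds shown leave open whether this shift belongs to the acetyl itself or would also come with another group on the same nitrogen, such as a methanesulfonyl or a benzoyl. They also leave open whether an acetyl would have a similar effect on a compound with a different group at the far end of the chain, such as a carboxylic acid.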